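The compounds below may be only part of what the source reports. "The series", "measured", "known", "first", "only" and "open" are said of these compounds alone.

Values so far in a functional assay on HeLa cells (Homo sapiens) for antiproliferative activity, read by WST assay, with a stated time of 24 h (on this read-out higher numbers stand for weaker inhibition and lower numbers for stronger inhibition), are these:
compound 1 `C=C[C@]1(C)CC[C@@H](C(=C)CNCCCC)C[C@H]1C(=C)C` gives 10800 nM
compound 2 `C=C[C@]1(C)CC[C@@H](C(=C)CNC2CCCCCCC2)C[C@H]1C(=C)C` gives 5900 nM

Compound 1 and compound 2 lie within the scatter of each other, so compound 1 holds no distinct place on these two numbers.

Compound 3 `C=C[C@]1(C)CC[C@@H](C(=C)CNC(C)C)C[C@H]1C(=C)C` has not been measured yet. Its change from compound 1 is isopropyl in place of butyl on an amine nitrogen and amounts to isopropyl in place of butyl on an amine nitrogen.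

Among the compounds with values here, one measured step bears on this change. The step of a 1.8-fold lower number from compound 1 to compound 2 (0.26 log units; within the scatter) also replaces the butyl on the amine nitrogen, and it stays within the scatter. A single step of that size gives no basis for a direction, so no shift beyond the scatter is expected for compound 3 in this assay on this evidence.

An estimated 1.0-fold higher number from compound 1 to compound 3 (0.01 log units; within the scatter) is all that is expected from this change. The expected value for compound 3 is 11000 nM with an estimated range from 6000 nM to 20000 nM in this read-out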

Compound 3, half-maximal inhibitory concentration: 40 nM
For compound 3 the middle estimate is 280-fold (2.44 log units) above the measured one; measured number below the stated range.
By their numbers in this assay, from the lowest: compound 3; then compounds 2 and 1 (each within the scatter of the next).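

In this assay the group on the amine nitrogen is not a neutral place on the core, as the first pair suggested: isopropyl gives a 270-fold lower number from compound 1 to compound 3 (2.43 log units; beyond the scatter) and a 150-fold lower number from compound 2 to compound 3 (2.17 log units; beyond the scatter), both large and beyond the scatter, whereas butyl and cyclooctyl gave only a 1.8-fold lower number from compound 1 to compound 2 (0.26 log units; within the scatter). The step from butyl to isopropyl changes the group only from 4 heavy atoms to 3, both without a ring, donor, acceptor or net charge, so a small change in this group can carry a very large step in this read-out. Group size does not order the three compounds, since cyclooctyl and butyl stay within the scatter of each other while isopropyl stands well apart from both, and nothing available explains this step.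

Going by these compounds, it remains open whether the low number belongs to isopropyl alone or extends to neighbouring groups on the same nitrogen, such as ethyl, cyclopropyl or tert-butyl. On these data alone, the effect of a second group on that nitrogen, such as a methyl, or of an acetyl in place of the isopropyl, also remains open.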